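Shortening the selenocyanate-bearing chain on a shared core

The source may hold more compounds than are shown below. What is called first, only, known or untested is meant among the compounds shown, and "the series" means these compounds.

Measured compounds:
- compound 1, `COc1ccc(N(C)c2nc(C)nc3ccccc23)cc1C(=O)OCC[Se]C#N`: 1480 nM
- compound 2, `COc1ccc(N(C)c2nc(C)nc3ccccc23)cc1OCCCC[Se]C#N`: 1350 nM

Both compounds were tested in a functional assay on MDA-MB-231 cells (Homo sapiens) for inhibition, read by MTT assay, with a stated time of 48 h; on this read-out higher numbers stand for weaker inhibition and lower numbers for stronger inhibition. Within the data shown here, compound 1 stands at the higher of the two numbers, with compound 2 as its only neighbour; the step of a 1.1-fold lower number from compound 1 to compound 2 (0.04 log units; within the scatter) shows that exchanging one chain for another of the same size on the shared core made no difference beyond the scatter.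

Compound 3, `COc1ccc(N(C)c2nc(C)nc3ccccc23)cc1C[Se]C#N`, has not yet been measured in this assay. It differs from compound 1 by a group of 4 heavy atoms (2 carbon, 1 nitrogen, 1 selenium; no ring) in place of a group of 8 heavy atoms (4 carbon, 1 nitrogen, 2 oxygen, 1 selenium; no ring), on an aromatic carbon, the change sitting on an aromatic carbon of a six-membered aromatic ring of carbon only, ortho to a methoxy group. Among the measured compounds shown here, the one comparable step, a 1.1-fold lower number from compound 1 to compound 2 (0.04 log units; within the scatter), suggests that altering this chain leaves the number roughly where it is, so compound 3 is expected to show a 1.0-fold higher number from compound 1 to compound 3 (0.01 log units; within the scatter). The estimate for compound 3 is therefore 1500 nM, within 700 nM to 3500 nM.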

Compound 3, half-maximal inhibitory concentration: 153 nM
Estimate against measurement, compound 3: 9.8-fold (0.99 log units) above, outside the stated range (below it).
By their numbers in this assay, from the lowest: compound 3; then compounds 2 and 1 (each within the scatter of the next).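

On the aromatic carbon ortho to a methoxy group, the number does respond to the chain: in this assay, the group of 4 heavy atoms gives a 9.7-fold lower number from compound 1 to compound 3 (0.99 log units; beyond the scatter), and in place of the other chain it gives an 8.8-fold lower number from compound 2 to compound 3 (0.95 log units; beyond the scatter). The two groups of 8 heavy atoms, one holding a carbonyl and the other not, stand within the scatter of each other, so their comparison alone gave no sign of this sensitivity. No measurement at hand gives a reason for the drop.

The compounds shown leave open whether the number follows chain length step by step or whether the shortest chain alone stands apart, since no chain of intermediate length appears among them. They also leave open how an amine or a carboxylic acid would fare in place of the selenocyanate.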